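This account rests on a few compounds, and the source may have more. Where it says the series, first, only, none or still open, it means among the compounds named here.

Compound 1 `CC1(C)OC[C@@H]2O[C@H](COCc3ccccc3)[C@@H](OCc3ccccc3)[C@H](OCc3ccccc3)[C@H]2O1`: 12500 nM
Compound 2 `CCCC[C@@H]1O[C@H](COCc2ccccc2)[C@@H](OCc2ccccc2)[C@H](OCc2ccccc2)[C@H]1O`: "not active" (no number reported)

In a functional assay on HL-60 cells (Homo sapiens) for antiproliferative activity, read by MTT assay (on this read-out higher numbers stand for weaker inhibition and lower numbers for stronger inhibition), compound 1 gives 12500 nM. In this assay compound 2 is reported only as "not active" (no number reported), with no number attached, so it cannot be placed on the same scale as compound 1. Compound 3 `CC(C)(C)C[C@@H]1O[C@H](COCc2ccccc2)[C@@H](OCc2ccccc2)[C@H](OCc2ccccc2)[C@H]1O` differs from compound 2 in one place: tert-butyl in place of propyl on a saturated chain carbon bound to a saturated ring carbon. Within the data shown here, with no number for compound 2, no step between the two can be sized; the expectation is that compound 3 stays in the weak range, near compound 1 or beyond it, with a real chance that this assay again reports no number. Compound 3 is estimated at 30000 nM, in the range 8000 nM to 100000 nM.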

Compound 3, half-maximal inhibitory concentration: "not active" (no number reported)
The entry for compound 3 holds no number, and the estimate cannot be compared.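

In this assay, among these compounds, compound 2 and compound 3 are both reported without a number, so no step between them can be read. Whether tert-butyl in place of propyl changes activity at all stays open, and no evidence shown bears on this result.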